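Chloro Added to Compound 1: What Its Inhibition Should Show

The source may hold more compounds than are shown below. What is called first, only, known or untested is meant among the compounds shown, and "the series" means these compounds.

Measured so far:
compound 1, `CN1C(=O)/C(=C(/S)N(C)c2ccccc2)C(=O)c2ccccc21`: 85%
compound 2, `COc1ccc2c(c1)c(O)c(C(=S)N(C)c1ccccc1)c(=O)n2C`: 99%

In a functional assay on the whole organism with Mus musculus as the target, at a dose of 32 mg/kg by the oral route (on this read-out higher numbers stand for more inhibition at the one dose given (going by the name of the read-out) and lower numbers for less inhibition), compound 1 gives the lower of the two numbers, and compound 2 stands higher by a gap beyond the usual scatter. Compound 3, `CN1C(=O)/C(=C(/S)N(C)c2ccccc2)C(=O)c2cc(Cl)ccc21`, differs from compound 1 by chloro in place of hydrogen on an aromatic carbon. For the measured compounds named here, no pair of measured compounds shows a change of this kind, so its size cannot be read from the data. The step of a number 1 percentage points higher from compound 1 to compound 3 (within the scatter) is expected to stay within the usual scatter of this assay. Compound 3 is therefore estimated at 86%, between 68% and 98%.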

Compound 3, a percentage reported as inhibition, in the whole organism at one dose (the size of the read-out at that dose, not a potency): 100%
Compound 3: the middle estimate sits 14 percentage points below what was measured, and the stated range ends below it.
By their numbers in this assay, from the lowest: compound 1; then compounds 2 and 3 (each within the scatter of the next).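

In this assay, chloro in place of hydrogen on this aromatic carbon gives a number 15 percentage points higher from compound 1 to compound 3 (beyond the scatter), so this position of the core of compound 1 takes a chlorine atom with a gain rather than a loss of inhibition at the one dose given. Compound 3 reaches 100%, which leaves this read-out no room to show a further rise. No measurement shown here bears on the reason for this step. The compounds shown leave open whether bromo, an amine or a carboxylic acid on the same carbon would match chloro, and whether chloro would do the same elsewhere on that ring.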